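The source may report more compounds than this note shows. Statements on the series, on what has been measured and on what is new or still open speak of the compounds shown alone.

Measured so far:
compound 1 `Cc1cc(OCc2ccccc2)c2nc(C)c(C)n2c1` — 71%
compound 2 `Cc1nc2c(OCc3ccccc3)cccn2c1N` — 96%

In a functional assay on the whole organism with Canis familiaris (Canis lupus familiaris) as the target, at a dose of 8 mg/kg by the oral route (on this read-out lower numbers stand for a weaker effect and higher numbers for a stronger effect at the one dose given), compound 2 gives 96%, the highest of the two numbers recorded. In this assay compound 1 gives 71%, a value that sits lower than that of compound 2 by a margin beyond the usual scatter. Compound 3 `CCc1nc2c(OCc3ccccc3)cccn2c1N` is the next member of the series and differs from compound 2 in one place: methyl in place of hydrogen on a saturated chain carbon bound to an aromatic carbon. Among the measured compounds shown here, no pair of measured compounds shows this particular change, so there is no measured step to lean on. Given that compound 2 already gives 96% in this assay, the room for a higher number is small, and a change of this size is expected to move the read-out little, if at all, beyond the scatter. For compound 3 the expected result in this assay is 90%, with a range from 72% to 99%. This corresponds to an expected step of a number 6 percentage points lower from compound 2 to compound 3 (within the scatter), most likely none beyond the scatter.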

Compound 3, a percentage reported as inhibition, in the whole organism at one dose (the size of the read-out at that dose, not a potency): 59%
Compound 3: the middle estimate sits 31 percentage points above what was measured; the whole stated range lies above it.
By their numbers in this assay, from the lowest: compound 3; then compound 1; then compound 2.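

Among the compounds shown here, the change from methyl to ethyl, with methyl in place of hydrogen on a saturated chain carbon bound to an aromatic carbon, gives in this assay a number 37 percentage points lower from compound 2 to compound 3 (beyond the scatter) and is the first measured step at this position. It shows that one added carbon here is enough to change the read-out at the one dose given, so the high number of compound 2 does not carry over to compound 3. The data shown offer no measurement that accounts for this drop.

The compounds shown leave open whether a longer chain such as propyl, or a trifluoromethyl group, would lower the read-out further at this place or restore it. They also leave open whether the same change from methyl to ethyl would have a similar effect on the core of compound 1.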